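This account rests on a few compounds, and the source may have more. Where it says the series, first, only, none or still open, it means among the compounds named here.

Working notes on the indole-substituted series in a functional assay on T47D cells (Homo sapiens) for inhibition, read by sulforhodamine B assay, with a stated time of 48 h; on this read-out lower numbers stand for stronger inhibition of growth and higher numbers for weaker inhibition of growth.

Compound 1 `COC(=O)[C@@]1(C)CCC=C2[C@@H]1CC[C@@H](C)[C@]2(C)Cc1c[nH]c2ccccc12` carries an unsubstituted indole and gives 4200 nM. Compound 2 `COC(=O)[C@@]1(C)CCC=C2[C@@H]1CC[C@@H](C)[C@]2(C)Cc1c[nH]c2ccc(C)cc12` gives 20000 nM, and compound 3 `COC(=O)[C@@]1(C)CCC=C2[C@@H]1CC[C@@H](C)[C@]2(C)Cc1c[nH]c2ccc(Cl)cc12` gives 17000 nM. On these three numbers compound 3 sits second highest; its nearest neighbour is compound 2, within the scatter, and its furthest is compound 1, beyond the scatter.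

The next member, compound 4 `COC(=O)[C@@]1(C)CCC=C2[C@@H]1CC[C@@H](C)[C@]2(C)Cc1c[nH]c2ccc(F)cc12`, differs from compound 3 by fluoro in place of chloro on an aromatic carbon. Among the compounds with values here, three measured steps bear on this position. The step of a 4.0-fold higher number from compound 1 to compound 3 (0.61 log units; beyond the scatter) and the step of a 4.8-fold higher number from compound 1 to compound 2 (0.68 log units; beyond the scatter) both show that a substituent here raises the number by a modest margin against hydrogen, while the step of a 1.2-fold lower number from compound 2 to compound 3 (0.07 log units; within the scatter) shows that exchanging one such substituent for another hardly moves it. As far as these compounds go, the fluoro substituent is untested, so its effect relative to chloro can only be bracketed between the hydrogen of compound 1 and the chloro of compound 3.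

Compound 4 is therefore expected to lie within the scatter of compound 3, with an estimated 1.5-fold lower number from compound 3 to compound 4 (0.19 log units; within the scatter), giving an expected value of 11000 nM in the range 4000 nM to 28000 nM.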

Compound 4, concentration for 50% growth inhibition: 3900 nM
For compound 4 the middle estimate is 2.8-fold (0.45 log units) above the measured one, outside the stated range (below it).
By their numbers in this assay, from the lowest: compounds 4 and 1 (each within the scatter of the next); then compounds 3 and 2 (each within the scatter of the next).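

In this assay, within the data shown here, this position on the aromatic carbon does not treat all substituents alike: the earlier compounds showed chloro and methyl within the scatter of each other, whereas fluoro parts from both, with a 4.4-fold lower number from compound 3 to compound 4 (0.64 log units; beyond the scatter) for the exchange of chloro and a 5.1-fold lower number from compound 2 to compound 4 (0.71 log units; beyond the scatter) for the exchange of methyl. Against hydrogen the picture is a 1.1-fold lower number from compound 1 to compound 4 (0.03 log units; within the scatter) and so fluoro cannot be told apart from the unsubstituted indole, which limits the earlier reading that a substituent here raises the number to methyl and chloro, with compound 4 as the compound that goes against it. Nothing at hand accounts for the separation of fluoro from chloro at this position.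

As far as these compounds go, all four compounds share the methyl ester on the core and vary only at this one aromatic carbon, so it stays open whether a methoxy group, an amine or a nitrile here would fall with compound 1 and compound 4 or with compound 2 and compound 3. Also open, from the compounds shown here alone, is how a carboxylic acid in place of the methyl ester would read in this assay on this series.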